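The compounds below may be only part of what the source reports. "The series", "measured", "known", "first", "only" and "open" are said of these compounds alone.

Of the compounds shown here, three share one core and have been tested in a functional assay on B16-F10 cells (Mus musculus) for antiproliferative activity, read by MTT assay, with a stated time of 48 h; on this read-out lower numbers stand for stronger inhibition and higher numbers for weaker inhibition. Compound 1 `CC(=O)N1N=C(c2ccc3ccccc3c2)OC1c1ccccc1` gives 2.57 ug/mL. Compound 2 `COc1ccc(C2OC(c3ccc4ccccc4c3)=NN2C(C)=O)cc1` gives 6.86 ug/mL, and compound 3 `CC(=O)N1N=C(c2ccc3ccccc3c2)OC1c1ccccc1Br` gives 6.98 ug/mL. Compound 3 thus has the highest number of the three, though the gap to compound 2 is within the scatter, while the step of a 2.7-fold higher number from compound 1 to compound 3 (0.43 log units; beyond the scatter) lies beyond it, as does a 2.7-fold higher number from compound 1 to compound 2 (0.43 log units; beyond the scatter). Between compound 2 and compound 3 the step of a 1.0-fold higher number from compound 2 to compound 3 (0.01 log units; within the scatter) is within the scatter.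

Compound 4 `CC(=O)N1N=C(c2ccc3ccccc3c2)OC1c1ccccc1Cl` differs from compound 3 in one place: chloro in place of bromo on an aromatic carbon. Among the compounds with values here, no measured step exchanges one halogen for another, so the closest guide is that adding bromo or methoxy to this ring changed the number only modestly, and swapping one of those for the other changed nothing beyond the scatter. A small step, within the scatter, is therefore expected for compound 4 in this assay, amounting to a 1.2-fold lower number from compound 3 to compound 4 (0.07 log units; within the scatter). Compound 4 is estimated at 6 ug/mL, within a range from 3 ug/mL to 12 ug/mL.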

Compound 4, half-maximal inhibitory concentration: 4.93 ug/mL
Estimate against measurement, compound 4: 1.2-fold (0.09 log units) above; the measured number falls inside the stated range.
By their numbers in this assay, from the lowest: compounds 1, 4, 2 and 3 (each within the scatter of the next, the first and the last beyond it).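

In this assay, within the data shown here, this is the first exchange of one halogen for another on this aromatic carbon, ortho to a large group, and with a 1.4-fold lower number from compound 3 to compound 4 (0.15 log units; within the scatter) it stays within the scatter. The 2-chlorophenyl and 4-methoxyphenyl groups also cannot be told apart, with a 1.4-fold lower number from compound 2 to compound 4 (0.14 log units; within the scatter) within the scatter, and chloro in place of hydrogen gives a 1.9-fold higher number from compound 1 to compound 4 (0.28 log units; within the scatter) and also stays within it, whereas bromo in place of hydrogen gave a 2.7-fold higher number from compound 1 to compound 3 (0.43 log units; beyond the scatter) and lies beyond it. So only bromo separates clearly from hydrogen here, yet bromo and chloro do not separate from each other, and no available evidence explains this pattern.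

Open, on these data alone, is how fluoro or iodo would compare on this same aromatic carbon. Also open, as far as these compounds go, is whether an amine or a carboxylic acid there would move the number beyond the scatter.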